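The source may report more compounds than this note shows. Statements on the series, on what has been measured and on what is new or still open speak of the compounds shown alone.

Measured so far in a functional assay on B16 cells (Mus musculus) for cytotoxicity, read by CCK-8 assay, with a stated time of 24 h; on this read-out lower numbers stand for stronger inhibition and higher numbers for weaker inhibition:

- Compound 1 `COc1cccc(-c2nc(N)c(Oc3ccccc3OC)c(Cl)n2)c1`: 23600 nM
- Compound 2 `COc1ccccc1Oc1c(N)nc(-c2cccc(C)c2)nc1OCCO`: 70900 nM

Only these two compounds have been measured, and they sit apart by more than the usual scatter. Compound 2, at 70900 nM, has the higher number and thus the weaker inhibition, while compound 1 reads 23600 nM.

The next compound is compound 3 `COc1cccc(-c2nc(N)c(Oc3ccccc3OC)c(OCCO)n2)c1`, which departs from compound 2 at one place on an aromatic carbon of a six-membered aromatic ring of carbon only, meta to a large group. Methoxy stands there in place of methyl, so that 3-methylphenyl becomes 3-methoxyphenyl: methoxy in place of methyl on an aromatic carbon.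

Going by the values given here, no pair of measured compounds shows this change on its own, which leaves the expectation without a direct precedent. The swap is small, and no step beyond the scatter is expected in this assay, with no direction favoured. The estimated 1.2-fold lower number from compound 2 to compound 3 (0.07 log units; within the scatter) reflects that expectation. For compound 3 the expected value is 60000 nM, with an estimated range from 28000 nM to 130000 nM.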

Compound 3, half-maximal inhibitory concentration: 30500 nM
Estimate against measurement, compound 3: 2.0-fold (0.29 log units) above; measured number inside the range.
By their numbers in this assay, from the lowest: compounds 1 and 3 (each within the scatter of the next); then compound 2.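

In this assay, going by these compounds alone, the change from methyl to methoxy on an aromatic carbon, meta to a large group, can now be read directly for the first time. It gives a 2.3-fold lower number from compound 2 to compound 3 (0.37 log units; beyond the scatter), so with 2-hydroxyethoxy held in place, this small swap brings a modest gain in inhibition rather than leaving the number unchanged. The second step, 2-hydroxyethoxy in place of chloro on an aromatic carbon with 3-methoxyphenyl held in place, gives a 1.3-fold higher number from compound 1 to compound 3 (0.11 log units; within the scatter), so in this pair the two groups cannot be told apart in this assay, and no measurement on hand offers an explanation for either step.

The compounds shown leave open whether the gain from methoxy carries over to a compound that has chloro in place of 2-hydroxyethoxy, since the single step comes from one pair. They also leave open how ethoxy, a hydroxyl or an amine would read at the same aromatic carbon, and whether a longer chain such as 3-hydroxypropoxy or a capped one such as 2-methoxyethoxy would read differently from 2-hydroxyethoxy.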